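The source may hold more compounds than are shown below. What is called first, only, known or untested is meant among the compounds shown, and "the series" means these compounds.

Of the compounds shown here, three built on one shared core have so far been measured, and they differ only in the group carried on an aromatic nitrogen of that core. Compound 1 `COc1ccc(-n2nc(-c3ccc(C(F)(F)F)cc3O)nc2-c2ccccc2O)cc1` gives 69% in a functional assay on PC-12 cells (Rattus norvegicus) for cytotoxicity, read by MTT assay, with stated times of 2 h and 24 h, tested at 1 uM; on this read-out higher numbers stand for a stronger effect at the one concentration tested and lower numbers for a weaker effect. Compound 2 `Oc1cc(C(F)(F)F)ccc1-c1nc(-c2ccccc2O)n(-c2ccccc2Cl)n1` gives 70.1% in this assay, and compound 3 `COc1cccc(-n2nc(-c3ccc(C(F)(F)F)cc3O)nc2-c2ccccc2O)c1` gives 68.3%. The three numbers sit close together: from compound 1 the step to compound 2 is a number 1.1 percentage points higher from compound 1 to compound 2 (within the scatter) and the step to compound 3 is a number 0.7 percentage points lower from compound 1 to compound 3 (within the scatter), while from compound 2 to compound 3 the step is a number 1.8 percentage points lower from compound 2 to compound 3 (within the scatter).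

Compound 4 `Cc1cc(C)cc(-n2nc(-c3ccc(C(F)(F)F)cc3O)nc2-c2ccccc2O)c1` has not yet been measured. Relative to compound 1 it carries 3,5-dimethylphenyl in place of 4-methoxyphenyl on an aromatic nitrogen. Both measured steps that exchange this same group, from compound 1 to compound 2 and from compound 1 to compound 3, stayed within the scatter, so another exchange at the same place is expected to produce no step beyond the scatter in this assay. The estimate for compound 4 is therefore 69%, within a range from 62% to 76%, which means an expected step of no change at the digits printed from compound 1 to compound 4 (within the scatter).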

Compound 4, a percentage reported as activity, at one concentration (the size of the read-out at that concentration, not a potency): 76.9%
Compound 4: middle estimate off by 7.9 percentage points, on the low side; measured number outside the range, above it.
By their numbers in this assay, from the lowest: compounds 3, 1, 2 and 4 (each within the scatter of the next).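

In this assay the 3,5-dimethylphenyl group, made of carbon only and with no hydrogen-bond acceptor where 4-methoxyphenyl has one, gives a number 7.9 percentage points higher from compound 1 to compound 4 (within the scatter) and so shows that losing this acceptor does not carry the read-out beyond the scatter. Against the other two groups the steps are a number 8.6 percentage points higher from compound 3 to compound 4 (within the scatter) and a number 6.8 percentage points higher from compound 2 to compound 4 (within the scatter), which leaves all four substituted phenyl groups on this aromatic nitrogen within the scatter of one another. Nothing available explains these numbers.

Going by these compounds, every group at this position is a substituted phenyl ring, so it remains open what a longer alkyl chain, or a phenyl ring bearing an amine or a carboxylic acid, would give here. On these data alone, the 2-hydroxyphenyl group and the rest of the shared core stay the same throughout, so their part in the read-out also remains open.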